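A few compounds are considered here, and "the series" means these few. Any claim that something is new, unique, unknown or untested is made for them only; others in the source may bear on it.

In a functional assay on L02 cells (Homo sapiens) for inhibition, read by MTT assay, with a stated time of 48 h (a lower number here means a stronger inhibitor, a higher number a weaker inhibitor), compound 2 `COc1ccc2c(=O)c(/C=C/C(=O)NCc3ccc(F)cc3)coc2c1` returns only a limit, > 200000 nM. Its close relative compound 1 `COc1ccc2c(=O)c(/C=C/C(=O)NCc3cccc(F)c3)coc2c1` likewise gives only a limit in this assay, > 200000 nM. Going by the values given here, the single measured step, a step that the two limits leave unreadable from compound 1 to compound 2, cannot be read in size or direction since both ends sit at the limit of > 200000 nM in this assay, at which 2 of the 2 values shown sit. Compound 3 `COc1ccc2c(=O)c(/C=C/C(=O)Nc3ccccc3OC)coc2c1` has not yet been tested. It differs from compound 2 by 2-methoxyphenyl in place of 4-fluorobenzyl on an amide-type nitrogen. Among the compounds with values here, no measured step bears directly on this exchange: the only step available, between compound 1 and compound 2, is itself unreadable and concerns the placing of fluorine on a fluorophenyl rather than the replacement of a benzyl group by a methoxyphenyl on the amide nitrogen. With both measured values resting at the limit, there is no number to anchor an expected size or direction in this assay. The estimate for compound 3 is therefore 200000 nM, within 60000 nM to 400000 nM, and it is expected to come back once more as a limit rather than a number. The step of a number no higher from compound 2 to compound 3 (the limit leaves the size open) is accordingly expected to be none beyond the scatter.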

Compound 3, half-maximal inhibitory concentration: > 200000 nM
Compound 3: only a limit was reported; the forecaster's own chance of this, stated with the estimate: 75%; the middle value lies on the limit itself.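

Compound 3 gives only a limit in this assay, so its steps from compound 1 and compound 2 cannot be read, and all three compounds rest at the same point: the limit of > 200000 nM in this assay, at which 3 of the 3 values shown sit. The compounds shown leave open whether moving the fluorine or exchanging 4-fluorobenzyl for 2-methoxyphenyl on the amide-type nitrogen alters inhibition at all.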